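Trioxolane series: microsomal clearance and an aminopropoxy variant

The compounds below may be only part of what the source reports. "The series", "measured", "known", "first", "only" and "open" are said of these compounds alone.

Measured so far in an ADME assay on microsomes from liver (Homo sapiens) for metabolic stability, read by LC-MS, tested at 1 uM; a lower number here means slower removal, a higher number faster removal of the compound:
compound 1, `NCCOCCOc1ccc([C@H]2CC[C@]3(CC2)OOC2(O3)C3CC4CC(C3)CC2C4)cc1`: < 7 mL.min-1.g-1
compound 2, `CC(C)(CN)Oc1ccc([C@H]2CC[C@]3(CC2)OOC2(O3)C3CC4CC(C3)CC2C4)cc1`: < 7 mL.min-1.g-1

The value for compound 1 in this assay is a limit of the assay, not a number. The value for compound 2 in this assay is likewise a limit of the assay. Both entries sit where the limit of < 7 mL.min-1.g-1 in this assay, at which 2 of the 2 values shown sit, puts them, so compound 1 stands at the lower end of what the assay can report and nothing more precise can be said of its place.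

Going by the values given here, the only step among the measured compounds is a step that the two limits leave unreadable from compound 1 to compound 2, and because of the limit of < 7 mL.min-1.g-1 in this assay, at which 2 of the 2 values shown sit, its size cannot be read.

Compound 3, `O[C@H]1CC[C@H](NCCCOc2ccc([C@H]3CC[C@]4(CC3)OOC3(O4)C4CC5CC(C4)CC3C5)cc2)CC1`, differs from compound 1 by ((4-hydroxycyclohexyl)amino)methyl in place of 2-aminoethoxy on a saturated chain carbon, two bonds along the chain from an oxygen on an aromatic ring. No measured step bears on this change, since the one step shown is unreadable at both ends. The expectation therefore rests on compound 1 alone, whose < 7 mL.min-1.g-1 is a limit. Compound 3 is expected to give 9 mL.min-1.g-1 in this assay, in the range 3 mL.min-1.g-1 to 27 mL.min-1.g-1, with a fair chance that the assay again reports only a limit. The step this estimate implies, an at least 1.2-fold higher number from compound 1 to compound 3 (0.10 log units; that floor lies within the scatter), is thus expected to be small and possibly unreadable.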

Compound 3, intrinsic clearance in microsomes: < 7 mL.min-1.g-1
Compound 3: only a limit was reported; the forecaster's own chance of this, stated with the estimate: 40%; middle value at least 1.2-fold (0.10 log units) from the limit.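

In this assay compound 3 gives < 7 mL.min-1.g-1, which is a limit of the assay and not a number. No step from compound 1 or compound 2 to compound 3 can be read, because all three compounds stand at the same limit: the limit of < 7 mL.min-1.g-1 in this assay, at which 3 of the 3 values shown sit.

The compounds shown leave open whether their clearances differ at all beneath that limit.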